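The source may report more compounds than this note shows. Statements on the series, on what has been measured and on what is new or still open speak of the compounds shown alone.

Compound 1 `O=C(COc1ccc2c(=O)ccoc2c1)Nc1cccc(NC(=O)c2ccccc2)c1` gives 120 nM in an assay on isolated protein for inhibition of Rho-associated protein kinase 1 (Homo sapiens), read by scintillation counting, radiometric assay and 33P incorporation, with a stated time of 40 min, in the presence of a further agent that is not named here; on this read-out lower numbers stand for stronger inhibition and higher numbers for weaker inhibition. Compound 2 `Cc1ccc(C(=O)Nc2cccc(NC(=O)COc3ccc4c(=O)ccoc4c3)c2)cc1` gives 183 nM in this assay, and compound 3 `CCCc1ccc(C(=O)Nc2cccc(NC(=O)COc3ccc4c(=O)ccoc4c3)c2)cc1` gives 143 nM in this assay. The three numbers lie close together: a 1.5-fold higher number from compound 1 to compound 2 (0.18 log units; within the scatter), a 1.2-fold higher number from compound 1 to compound 3 (0.08 log units; within the scatter) and a 1.3-fold lower number from compound 2 to compound 3 (0.11 log units; within the scatter) all fall within the scatter. Compound 3 therefore cannot be set apart from either neighbour; its number is the second highest of the three, with compound 1 nearest and compound 2 furthest, and neither gap exceeds the scatter.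

Compound 4 `O=C(COc1ccc2c(=O)ccoc2c1)Nc1cccc(NC(=O)c2ccc(F)cc2)c1` carries the change (fluoro in place of propyl on an aromatic carbon), on an aromatic carbon of a six-membered aromatic ring of carbon only. The measured steps that bear on it are those at this same position: a 1.5-fold higher number from compound 1 to compound 2 (0.18 log units; within the scatter) and a 1.2-fold higher number from compound 1 to compound 3 (0.08 log units; within the scatter) show that putting a methyl or a propyl there left the number within the scatter, and a 1.3-fold lower number from compound 2 to compound 3 (0.11 log units; within the scatter) shows the same for lengthening the chain by an ethyl. Going by the values given here, no measured step exchanges a carbon substituent for fluoro, so the evidence is indirect. Compound 4 is expected to show a 1.1-fold lower number from compound 3 to compound 4 (0.04 log units; within the scatter), given that a 1.5-fold higher number from compound 1 to compound 2 (0.18 log units; within the scatter) and a 1.2-fold higher number from compound 1 to compound 3 (0.08 log units; within the scatter) stayed within the scatter. Compound 4 is therefore estimated at 130 nM in this assay, with a range from 60 nM to 280 nM.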

Compound 4, half-maximal inhibitory concentration: 129 nM
The estimate for compound 4 lay 1.0-fold (0.00 log units) above the measured number, and the stated range covers the measured number.
By their numbers in this assay, from the lowest: compounds 1, 4, 3 and 2 (each within the scatter of the next).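

Fluoro is the first group at this place that is not hydrogen or a carbon chain, and it brings a fluorine atom onto an aromatic carbon of a six-membered aromatic ring of carbon only, para to a large group. In this assay, all three new comparisons stay within the scatter: a 1.1-fold lower number from compound 3 to compound 4 (0.04 log units; within the scatter), a 1.4-fold lower number from compound 2 to compound 4 (0.15 log units; within the scatter) and a 1.1-fold higher number from compound 1 to compound 4 (0.03 log units; within the scatter). Among these four compounds, then, the number does not separate hydrogen, fluoro, methyl and propyl at this place, so the flat picture seen with the two carbon chains now also holds for a single fluorine atom, although nothing shown here accounts for this.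

All four groups leave open whether an amine, a carboxylic acid, a hydroxyl group or a chain longer than propyl at this place would move the number beyond the scatter. The compounds shown also leave open whether fluoro or chloro elsewhere on this ring, or a change in the shared core, would do so, and how any of these compounds would behave on other kinases or in cells.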